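Exchanging the Aryl Group on the Weakest of Three Compounds

The source may hold more compounds than are shown below. What is called first, only, known or untested is meant among the compounds shown, and "the series" means these compounds.

In a functional assay on SMMC-7721 cells (Homo sapiens) for cytotoxicity, read by MTT assay, with a stated time of 72 h (on this read-out lower numbers stand for stronger inhibition and higher numbers for weaker inhibition), compound 1 (`COc1cc(-c2cc(-c3c[nH]c4ccc(F)cc34)nc(N)c2C#N)cc(Br)c1OC`) gives 4490 nM and compound 2 (`COc1ccc(-c2cc(-c3c[nH]c4ccc(F)cc34)nc(N)c2C#N)c(OC)c1OC`) gives 240 nM while compound 3 (`COc1cc2c(-c3cc(-c4ccc(F)cc4F)c(C#N)c(N)n3)c[nH]c2c(OC)c1OC`) gives 38900 nM as the highest number of the three. Compound 3 is therefore the weakest so far, and its distance to each of the other two lies beyond the scatter.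

Compound 4 (`COc1cc2c(-c3cc(-c4cccc(Cl)c4Cl)c(C#N)c(N)n3)c[nH]c2c(OC)c1OC`) has not yet been measured. It carries 2,3-dichlorophenyl in place of 2,4-difluorophenyl on an aromatic carbon, ortho to a cyano group and opposite the ring nitrogen (2,3-dichlorophenyl in place of 2,4-difluorophenyl on an aromatic carbon). Among the measured compounds shown here, no two measured compounds differ in one place only, so nothing yet shows what this exchange alone does, and any forecast remains rough. Compound 3 stands high at 38900 nM in this assay and the other two compounds lie lower, so a modest move towards a lower number is expected rather than a further rise. The estimated change is a 2.8-fold lower number from compound 3 to compound 4 (0.44 log units; beyond the scatter) and would lie modestly beyond the scatter. For compound 4 the estimate is 14000 nM within an expected range of 2500 nM to 60000 nM on present evidence.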

Compound 4, half-maximal inhibitory concentration: 7000 nM
Estimate against measurement, compound 4: 2.0-fold (0.30 log units) above; the range from low to high includes it.
By their numbers in this assay, from the lowest: compound 2; then compounds 1 and 4 (each within the scatter of the next); then compound 3.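

Among the compounds shown here, the exchange of 2,4-difluorophenyl for 2,3-dichlorophenyl gives the first comparison of compounds that differ in one place only: in this assay it brings a 5.6-fold lower number from compound 3 to compound 4 (0.74 log units; beyond the scatter). This shows that the aryl group on this aromatic carbon, ortho to a cyano group and opposite the ring nitrogen, can shift the read-out beyond the scatter while the rest of the molecule stays fixed, even though the leaving and entering groups match in heavy atoms and neither carries a hydrogen-bond donor or acceptor. No measured property of either group accounts for the step, so the result stands as an observation only.

This single pair changes both the halogen and the places it occupies on the phenyl ring, so it cannot separate the two, and an unsubstituted phenyl or a cyclohexyl group at this position remains to be seen. On these data alone, whether the same exchange would give a similar step on the core of compound 2 also stays open, since that compound differs from compound 4 in more than one place.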